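The source may hold more compounds than are shown below. What is called first, only, known or untested is meant among the compounds shown, and "the series" means these compounds.

The measured compounds:
Compound 1, `CN1CCN(c2ccc(Nc3ncc4nc(Nc5ccc(F)cc5)n([C@H]5CCCNC5)c4n3)cc2)CC1`: 38 nM
Compound 2, `CN1CCN(c2ccc(Nc3ncc4nc(Nc5ccc(F)cc5)n([C@H]5CCCN(C(=O)CO)C5)c4n3)cc2)CC1`: 1.8 nM
Compound 3, `CN1CCN(c2ccc(Nc3ncc4nc(Nc5ccc(F)cc5)n([C@H]5CCCC(NC(=O)OC(C)(C)C)C5)c4n3)cc2)CC1`: 120 nM

All three were tested in a functional assay on HCC827 cells (Homo sapiens) for antiproliferative activity, read by MTT assay, with a stated time of 72 h; on this read-out higher numbers stand for weaker inhibition and lower numbers for stronger inhibition. Compound 1 stands second highest of the three numbers: compound 3 gives a higher number, compound 2 a lower one. Going by the values given here, the only step measured in a single place runs from compound 1 to compound 2, a 21-fold lower number from compound 1 to compound 2 (1.32 log units; beyond the scatter), where a (hydroxymethyl)carbonyl group replaces hydrogen on an amine nitrogen in a ring.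

Compound 4, `CN1CCN(c2ccc(Nc3ncc4nc(Nc5ccc(F)cc5)n(-c5cccc(NC(=O)CO)c5)c4n3)cc2)CC1`, has not yet been measured. It differs from compound 1 in one place: 3-(((hydroxymethyl)carbonyl)amino)phenyl in place of piperidin-3-yl on an aromatic nitrogen. The change brings in the same (hydroxymethyl)carbonyl amide that compound 2 carries, but here it sits on an aromatic ring rather than on a ring amine, and at the same time the saturated ring itself is exchanged for an aromatic one. Among the compounds with values here, no measured step covers such a ring exchange, so the expectation rests on compound 2 alone, because compound 2 gave 1.8 nM against compound 1 at 38 nM. Going by these compounds, whether that gain carries over to an aromatic setting is untested, so the expected step is set smaller.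

Compound 4 is therefore expected to give a lower number than compound 1, a step of a 3.2-fold lower number from compound 1 to compound 4 (0.50 log units; beyond the scatter). Compound 4 is estimated at 12 nM, with a range from 3 nM to 50 nM.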

Compound 4, half-maximal inhibitory concentration: 7.5 nM
Estimate against measurement, compound 4: 1.6-fold (0.20 log units) above; measured number inside the range.
By their numbers in this assay, from the lowest: compound 2; then compound 4; then compound 1; then compound 3.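

In this assay, putting 3-(((hydroxymethyl)carbonyl)amino)phenyl in place of piperidin-3-yl on the aromatic nitrogen gives a 5.1-fold lower number from compound 1 to compound 4 (0.70 log units; beyond the scatter), so a saturated ring is not required at this position for a low number. The second comparison keeps the (hydroxymethyl)carbonyl group on both sides and changes what carries it: 3-(((hydroxymethyl)carbonyl)amino)phenyl in place of 1-((hydroxymethyl)carbonyl)piperidin-3-yl gives a 4.2-fold higher number from compound 2 to compound 4 (0.62 log units; beyond the scatter), so the aromatic version keeps part of the gain seen with the saturated ring, but not all of it. Nothing available explains why the two carriers of this group give different numbers.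

Going by these compounds, how a plain phenyl group on the aromatic nitrogen would compare with compound 4 stays open, so the shares of the aromatic ring and of the amide in the step from the piperidin-3-yl group cannot be separated. Also open, on these data alone, is whether an amine in place of the hydroxyl of the (hydroxymethyl)carbonyl group, or a longer chain ending in hydroxyl, would keep the number as low on the phenyl ring.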